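Amide substituent change at a limit-bound position

The source may hold more compounds than are shown below. What is called first, only, known or untested is meant among the compounds shown, and "the series" means these compounds.

Compound 1 `CCn1c(C(=O)N(CCC#N)CCC#N)ccc1C(CC)(CC)c1ccc(OCCC(O)(CC)CC)c(C)c1` and compound 2 `CCOc1ccc(NC(=O)c2ccc(C(CC)(CC)c3ccc(OCCC(O)(CC)CC)c(C)c3)n2CC)cc1` share one core and differ only in the group attached to the carbonyl carbon. In a functional assay on MCF7 cells (Homo sapiens) for antiproliferative activity, read by MTT assay, with a stated time of 48 h (on this read-out lower numbers stand for stronger inhibition and higher numbers for weaker inhibition), compound 1 gives > 50000 nM, a limit of the assay rather than a number. In this assay compound 2 gives > 50000 nM, likewise a limit. The step that the two limits leave unreadable from compound 1 to compound 2 therefore has no readable size, as both values sit at the limit of > 50000 nM in this assay, at which 2 of the 2 values shown sit. Compound 3 `CCn1c(C(=O)NC(CO)CCO)ccc1C(CC)(CC)c1ccc(OCCC(O)(CC)CC)c(C)c1` carries 3-hydroxy-1-(hydroxymethyl)propyl in place of 4-ethoxyphenyl on an amide-type nitrogen. Among the compounds with values here, no measured step bears on this change: the only step between measured compounds runs from one limit to another and gives no size. Compound 2 stands at the limit in this assay, and nothing shown points to a readable step for compound 3 in either direction. Compound 3 is expected to give 60000 nM in this assay, between 15000 nM and 250000 nM, most likely again reported only as a limit. The expected step is a step that the limit leaves unreadable from compound 2 to compound 3.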

Compound 3, half-maximal inhibitory concentration: 31400 nM
Beside the measured number, compound 3's estimate is 1.9-fold (0.28 log units) above it; low and high end bracket the measured number.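

In this assay, compound 3 is the only one of the three to give a number rather than a limit, with 3-hydroxy-1-(hydroxymethyl)propyl on the amide-type nitrogen; the other two stay at a limit: the limit of > 50000 nM in this assay, at which 2 of the 3 values shown sit.

From the compounds shown here alone, the steps that can be read are an at least 1.5-fold lower number from compound 2 to compound 3 (0.20 log units; that floor lies within the scatter) and an at least 1.5-fold lower number from compound 1 to compound 3 (0.20 log units; that floor lies within the scatter); each gives only a floor, so the true size of the change stays unknown and a real difference is not established. The step from compound 1 to compound 2 cannot be read, since two limits give no size.

Going by these compounds, it remains open whether both hydroxyl groups of the entering chain are needed for a measurable number. A 2-hydroxyethyl chain, a carboxylic acid or an amine on the amide-type nitrogen would test how far this position can move the value.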